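A few compounds are considered here, and "the series" means these few. Any claim that something is new, unique, unknown or untested is made for them only; others in the source may bear on it.

Compound 1 `COc1cc(-c2cc(/C=C/C(=O)c3ccc(N)cc3)[nH]n2)cc(OC)c1OC` gives 73% in a functional assay on BT-549 cells (Homo sapiens) for cytotoxicity, read by sulforhodamine B assay, with a stated time of 48 h, tested at 1 uM (a higher number here means a weaker effect of the compound at the concentration tested, a lower number a stronger effect), and compound 2 `COc1ccc(-c2cc(/C=C/C(=O)c3ccc(N)cc3)[nH]n2)cc1OC` gives 80% in this assay; the step of a number 7 percentage points higher from compound 1 to compound 2 (within the scatter) lies within the scatter, so compound 1 stands together with compound 2 and the two numbers cannot be told apart. Compound 3 `COc1cc(-c2cc(/C=C/C(=O)c3ccc(F)c(F)c3)[nH]n2)cc(OC)c1OC` differs from compound 1 by 3,4-difluorophenyl in place of 4-aminophenyl on a carbonyl carbon. Within the data shown here, no measured step touches the carbonyl carbon; the only step known concerns a methoxy on an aromatic carbon and was within the scatter. No step beyond the scatter is therefore expected in this assay, estimated as a number 3 percentage points lower from compound 1 to compound 3 (within the scatter). Compound 3 is expected at 70%, between 40% and 95%.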

Compound 3, a percentage reported as activity, at one concentration (the size of the read-out at that concentration, not a potency): 92%
The estimate for compound 3 lay 22 percentage points below the measured number; the range from low to high includes it.
By their numbers in this assay, from the lowest: compounds 1 and 2 (each within the scatter of the next); then compound 3.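

In this assay, 3,4-difluorophenyl in place of 4-aminophenyl on a carbonyl carbon gives a number 19 percentage points higher from compound 1 to compound 3 (beyond the scatter) and so weakens the effect at the concentration tested. Among these compounds, this is the first step beyond the scatter, showing that this position can register a change in this assay, which the methoxy step did not show. Nothing available accounts for the step. Going by these compounds, the swap removes the amine and brings in two fluorines at once, and which of these carries the step stays open. A plain phenyl or a 4-fluorophenyl on the carbonyl carbon would separate the two.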